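Chloro for ethoxycarbonyl on the urea series

The source may hold more compounds than are shown below. What is called first, only, known or untested is meant among the compounds shown, and "the series" means these compounds.

Measured so far:
compound 1, `CCOC(=O)c1cccc(NC(=O)N[C@H](C)c2ccccc2)c1`, 88%
compound 2, `CCOC(=O)c1cccc(NC(=O)N[C@@H](C)c2ccccc2)c1`, 96%
compound 3, `C[C@@H](NC(=O)Nc1ccccc1Cl)c1ccccc1`, 93%

In an ADME assay on the whole organism with Oryza sativa as the target, tested at 10 uM (on this read-out lower numbers stand for a stronger effect and higher numbers for a weaker effect at the one concentration tested), compound 2 sits at the high end of the three numbers, but compound 3 and compound 1 both lie within the usual scatter of it, so no order among them can be read. Among the compounds with values here, the one measured step, a number 8 percentage points higher from compound 1 to compound 2 (within the scatter), rests on the fact that compounds 1 and 2 differ only in the configuration as drawn and says nothing about substituents on the aromatic ring.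

Compound 4, `C[C@H](NC(=O)Nc1cccc(Cl)c1)c1ccccc1`, is the next point. Relative to compound 2 the change is chloro in place of ethoxycarbonyl on an aromatic carbon. Within the data shown here, no measured step covers this exchange. Compound 3, which also carries a chloro on its aromatic ring, gives 93% in this assay, and that number sits within the scatter of compound 2, so the chloro does not point to a large move on its own.

With nothing in hand to suggest a shift beyond the scatter, the step of a number 4 percentage points lower from compound 2 to compound 4 (within the scatter) is expected to stay small. Compound 4 is therefore estimated at 92%, with a range from 80% to 100%.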

Compound 4, a percentage reported as activity, at one concentration (the size of the read-out at that concentration, not a potency): 103%
The estimate for compound 4 lay 11 percentage points below the measured number, and the stated range ends below it.
By their numbers in this assay, from the lowest: compounds 1, 3, 2 and 4 (each within the scatter of the next, the first and the last beyond it).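

In this assay, the exchange of ethoxycarbonyl, with its 5 heavy atoms and 2 hydrogen-bond acceptors, for chloro, with 1 heavy atom and no hydrogen-bond acceptors, now has a measured step: a number 7 percentage points higher from compound 2 to compound 4 (within the scatter). Within the data shown here, the earlier compounds gave a step only for a change of configuration, so this is the first reading of a substituent change at this aromatic carbon, meta to a large group, and on this pair, a large difference between the two groups in size and acceptor count comes with no change in the read-out beyond the scatter. Nothing at hand gives a reason for the size of this step.

From the compounds shown here alone, whether any group at this aromatic carbon, such as an amine, a carboxylic acid or a methoxy, would shift the number beyond the scatter remains open, since one exchange on one pair cannot define what the position allows. Also open, going by these compounds, is whether the same exchange would read alike on the configuration drawn in compound 1, where the number for the ethoxycarbonyl compound is 88%.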